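The source may hold more compounds than are shown below. What is called first, only, known or untested is meant among the compounds shown, and "the series" means these compounds.

Measured in a physicochemical assay for solubility, in phosphate buffer, measured as kinetic solubility, with a stated time of 24 h, at pH 6.5; on this read-out higher numbers stand for higher solubility and lower numbers for lower solubility:
- compound 1 `Cc1ccc(NC(=O)c2cc(Oc3ccc(S(C)(=O)=O)cc3)cc(OC(C)C)c2)nc1`: 1400 nM
- compound 2 `Cc1cc(=O)[nH]c(-c2cc(Oc3ccc(S(C)(=O)=O)cc3)cc(OC(C)C)c2)n1`: 15000 nM

Not yet measured: compound 3 `COc1cnc(-c2cc(Oc3ccc(S(C)(=O)=O)cc3)cc(OC(C)C)c2)[nH]c1=O`.

Of the two numbers in this assay, the higher belongs to compound 2 at 15000 nM. Compound 3 carries a group of 9 heavy atoms (5 carbon, 2 nitrogen, 2 oxygen; one six-membered aromatic ring with 2 hetero atoms) in place of a group of 8 heavy atoms (5 carbon, 2 nitrogen, 1 oxygen; one six-membered aromatic ring with 2 hetero atoms), on an aromatic carbon, on an aromatic carbon meta to an isopropoxy group. Among the measured compounds shown here, only one measured step bears on this, an 11-fold higher number from compound 1 to compound 2 (1.03 log units; beyond the scatter), which is large and beyond the scatter. It concerns the same attachment point but a different exchange of groups, so it gives no direction here. The expected outcome is a 1.2-fold lower number from compound 2 to compound 3 (0.06 log units; within the scatter), with no change beyond the scatter anticipated. For compound 3 the estimated value is 13000 nM, with an expected range of 4000 nM to 45000 nM.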

Compound 3, solubility: 7100 nM
Estimate against measurement, compound 3: 1.8-fold (0.26 log units) above; the measured number falls inside the stated range.
By their numbers in this assay, from the lowest: compound 1; then compound 3; then compound 2.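

In this assay, exchanges at this aromatic carbon, meta to an isopropoxy group, can shift the number even between groups that each hold a six-membered aromatic ring with 2 hetero atoms: the reading shows a 2.1-fold lower number from compound 2 to compound 3 (0.32 log units; beyond the scatter), a modest step. The higher level over compound 1 is kept, with a 5.1-fold higher number from compound 1 to compound 3 (0.71 log units; beyond the scatter). Nothing available explains either step.

Open, going by these compounds, is whether the oxygen counted in the entering group accounts for the step from compound 2. Also open, on these data alone, is how a ring carrying an amine or a carboxylic acid would read at this attachment point.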